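Urea-to-benzimidazole swap at the ring nitrogen: cytotoxicity outlook

The source may hold more compounds than are shown below. What is called first, only, known or untested is meant among the compounds shown, and "the series" means these compounds.

Of the compounds shown here, three have been read in an ADME assay on MT4 cells (Homo sapiens) for cytotoxicity, read by MTT assay; a lower number here means that less compound is tolerated, a higher number that more compound is tolerated. Compound 1 `Cc1nc(NC(=O)NC2CCCCC2)c(C)c(C(OC(C)(C)C)C(=O)O)c1-c1ccc(Cl)cc1` gives 16000 nM. Among the compounds with values here, compound 3 `Cc1nc(NC(=O)NC2CCCCC2)c(C)c(C(OC(C)(C)C)C(=O)O)c1-c1ccc(C(F)(F)F)cc1` gives 9800 nM; the only single-point step measured so far, a 1.6-fold lower number from compound 1 to compound 3 (0.21 log units; within the scatter), stays within the scatter. Compound 2 `Cc1ccc(-c2c(C)nc(NC(=O)NC3CCOCC3)c(C)c2C(OC(C)(C)C)C(=O)O)cc1C` gives 29000 nM, the highest number of the three: against compound 1 the gap is within the scatter, against compound 3 it lies beyond it, so compound 2 can only be said to be tolerated at least as well as the other two.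

Compound 4 `Cc1ccc(-c2c(C)nc(Nc3nc4ccccc4n3C)c(C)c2C(OC(C)(C)C)C(=O)O)cc1C` differs from compound 2 by 1-methyl-1H-benzimidazol-2-yl in place of (oxan-4-yl)carbamoyl on a nitrogen on an aromatic ring. Within the data shown here, no measured step touches this nitrogen; the one step on record concerns the aromatic substituent and was small. There is therefore no basis for expecting a shift beyond the scatter in this assay, and the expected step of a 1.3-fold lower number from compound 2 to compound 4 (0.12 log units; within the scatter) is set near zero with a wide allowance. Compound 4 is estimated at 22000 nM, with a range from 7000 nM to 70000 nM.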

Compound 4, half-maximal cytotoxic concentration: 14000 nM
The estimate for compound 4 lay 1.6-fold (0.20 log units) above the measured number; the range from low to high includes it.
By their numbers in this assay, from the lowest: compounds 3, 4, 1 and 2 (each within the scatter of the next, the first and the last beyond it).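

The nitrogen on an aromatic ring now has its first measured step in this assay: 1-methyl-1H-benzimidazol-2-yl in place of (oxan-4-yl)carbamoyl gives a 2.1-fold lower number from compound 2 to compound 4 (0.32 log units; beyond the scatter). The position is therefore not silent in this assay, although the shift is modest and based on a single pair, and the whole group changes at once, so no part of it can be singled out as carrying the shift. Nothing available explains the direction or size of the step.

Open, as far as these compounds go, is how simpler groups on this nitrogen would read, such as acetyl, methyl or a benzimidazole without its 1-methyl group. Also open, from the compounds shown here alone, is whether the same exchange gives a similar step with the aromatic substituents of compound 1 and compound 3.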